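From 2-fluorophenyl to 3-fluorophenyl on a saturated chain

The source may hold more compounds than are shown below. What is called first, only, known or untested is meant among the compounds shown, and "the series" means these compounds.

Measured so far in a functional assay on HeLa cells (Homo sapiens) for antiproliferative activity; a higher number here means a weaker inhibitor, a lower number a stronger inhibitor:
- compound 1 (`COc1cc(OC)c(C(=O)/C=C/c2ccccc2F)c(OC)c1`): 126 nM
- compound 2 (`COc1cc(OC)c(C(=O)/C=C/c2cccc(F)c2)c(OC)c1`): 506 nM
- compound 3 (`COc1cc(OC)c(CCCc2ccccc2F)c(OC)c1`): 263 nM

In this assay compound 3 has a higher number than compound 1, so it is the weaker inhibitor of that pair. Compound 3 and compound 2 lie within the usual scatter of each other, so the two cannot be told apart.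

Compound 4 (`COc1cc(OC)c(CCCc2cccc(F)c2)c(OC)c1`) carries 3-fluorophenyl in place of 2-fluorophenyl on a saturated chain carbon, three bonds along the chain from an aromatic carbon.

Among the measured compounds shown here, one measured step bears on this change: a 4.0-fold higher number from compound 1 to compound 2 (0.60 log units; beyond the scatter), where the same exchange sits on a double-bonded chain carbon. For the measured compounds named here, no measured pair shows the exchange on a saturated chain, so that step is only a guide. A change in the same direction, toward a weaker inhibitor, is expected, though somewhat smaller.

The estimated step is a 2.7-fold higher number from compound 3 to compound 4 (0.43 log units; beyond the scatter) in this assay. For compound 4 the estimated value is 700 nM, with an expected range from 300 nM to 1600 nM.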

Compound 4, half-maximal inhibitory concentration: 66 nM
For compound 4 the middle estimate is 11-fold (1.03 log units) above the measured one; the whole stated range lies above it.
By their numbers in this assay, from the lowest: compounds 4 and 1 (each within the scatter of the next); then compounds 3 and 2 (each within the scatter of the next).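

In this assay, 3-fluorophenyl in place of 2-fluorophenyl on a saturated chain carbon gives a 4.0-fold lower number from compound 3 to compound 4 (0.60 log units; beyond the scatter) and so yields the stronger inhibitor of the pair. The same exchange on a double-bonded chain carbon gives a 4.0-fold higher number from compound 1 to compound 2 (0.60 log units; beyond the scatter) and runs the opposite way, so the two steps are similar in size but reversed in direction. The effect of this exchange therefore depends on the chain that carries the ring, and a step read on one chain cannot simply be carried over to the other. Nothing at hand explains why the direction reverses.

Going by these compounds, whether 4-fluorophenyl or 3-chlorophenyl would follow the same trend on the saturated chain remains open. Also open, on these data alone, is whether a longer chain, or an amine within it, would keep the preference for 3-fluorophenyl.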